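Notes on a shared-core series: fluoro to methoxy

This account rests on a few compounds, and the source may have more. Where it says the series, first, only, none or still open, it means among the compounds named here.

Measured so far:
compound 1 `COc1cc(-n2ncnc2-c2cccc([N+](=O)[O-])c2)cc(OC)c1OC` — > 10000 nM
compound 2 `COc1cc(-c2ncnn2-c2cccc(N)c2)cc(OC)c1OC` — > 10000 nM
compound 3 `COc1cc(-n2ncnc2-c2ccc(F)cc2)cc(OC)c1OC` — > 10000 nM

All three readings in a functional assay on HeLa cells (Homo sapiens) for antiproliferative activity, read by MTT assay, with a stated time of 72 h (a higher number here means a weaker inhibitor, a lower number a stronger inhibitor), are limits of the assay rather than numbers. Compound 3 stands at the limit > 10000 nM, which is not a measured value. The same holds for compound 1 and for compound 2; the three compounds therefore cannot be ordered against one another, and none can be called the strongest or weakest. The only firm fact on the series is the limit of > 10000 nM in this assay, at which 3 of the 3 values shown sit.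

Among the measured compounds shown here, no pair among the measured compounds differs in a single place, so no measured step exists to lean on. Compound 4 `COc1ccc(-c2ncnn2-c2cc(OC)c(OC)c(OC)c2)cc1` differs from compound 3 in one place: methoxy in place of fluoro on an aromatic carbon.

With nitro, amino and fluoro variants all returning limits, compound 4 is expected to behave in the same way in this assay. The expected step that the limit leaves unreadable from compound 3 to compound 4 is none beyond the usual scatter. Compound 4 is estimated at 15000 nM in this assay, with a range from 3000 nM to 60000 nM, and most likely the assay will again report only a limit for compound 4.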

Compound 4, half-maximal inhibitory concentration: 280 nM
The estimate for compound 4 lay 54-fold (1.73 log units) above the measured number, and the stated range ends above it.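

In this assay, among the compounds shown here, this is the first place where a single change moves the reading off the limit: methoxy in place of fluoro on an aromatic carbon, para to a large group, gives an at least 35-fold lower number from compound 3 to compound 4 (1.55 log units; beyond the scatter), beyond the scatter. As far as these compounds go, the shared core can therefore return a measured number, and the group at this one position decides between a limit and a reading for this pair, although the full size of the step stays unknown, as the value of compound 3 is a limit and the step is only a bound. Compound 4 is the only measured number among the compounds shown, and the others rest at the same ceiling: the limit of > 10000 nM in this assay, at which 3 of the 4 values shown sit.

Open, from the compounds shown here alone, is whether methoxy is special at this carbon, or whether an ethoxy, a hydroxyl, a methyl or a dimethylamino group in the same place would also give a measured number. Also open, going by these compounds, is how far the 4-fluorophenyl to 4-methoxyphenyl result reaches, since a single pair in a single cell line says nothing yet about a methoxy group elsewhere on that ring.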